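The compounds below may be only part of what the source reports. "The series", "measured", "known", "first", "only" and "open" are said of these compounds alone.

Solubility readings in a physicochemical assay for solubility, with a stated time of 18 h, at pH 7.4; on this read-out lower numbers stand for lower solubility and higher numbers for higher solubility:

compound 1 `Fc1ccc(-c2ccc3c(NCCCNCc4ccco4)ccnc3c2)cc1`: 32000 nM
compound 2 `COc1ccccc1Oc1ccc2c(NCCCNCc3ccco3)ccnc2c1`: 14500 nM
compound 3 `c1ccc(-c2ccc3c(NCCCNCc4ccco4)ccnc3c2)cc1`: 32000 nM

Compound 3 stands level with compound 1 at the digits shown, the step of no change at the digits printed from compound 1 to compound 3 (within the scatter) staying within the scatter, whereas a 2.2-fold higher number from compound 2 to compound 3 (0.34 log units; beyond the scatter) lies beyond it, so compound 2 is the one number set apart among the three. Compound 4 `COc1ccc(Oc2ccc3c(NCCCNCc4ccco4)ccnc3c2)cc1` has not yet been measured in this assay. It differs from compound 3 in one place: 4-methoxyphenoxy in place of phenyl on an aromatic carbon. The measured step that bears on this is a 2.2-fold higher number from compound 2 to compound 3 (0.34 log units; beyond the scatter), which runs the same exchange in reverse with 2-methoxyphenoxy rather than 4-methoxyphenoxy entering; the step of a 2.2-fold lower number from compound 1 to compound 2 (0.34 log units; beyond the scatter) points the same way. A modest fall in this assay of about that size is therefore expected for compound 4, the expected step being a 2.1-fold lower number from compound 3 to compound 4 (0.33 log units; beyond the scatter). Compound 4 is estimated at 15000 nM, with a range of 7000 nM to 32000 nM.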

Compound 4, solubility: 14500 nM
For compound 4 the middle estimate is 1.0-fold (0.01 log units) above the measured one; the range from low to high includes it.
By their numbers in this assay, from the lowest: compounds 2 and 4 (each within the scatter of the next); then compounds 1 and 3 (each within the scatter of the next).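

In this assay the 4-methoxyphenoxy group also gives a fall from the phenyl compound (a 2.2-fold lower number from compound 3 to compound 4 (0.34 log units; beyond the scatter)), so the drop is no longer confined to the 2-methoxyphenoxy group, and exchanging one methoxyphenoxy group for the other leaves the reading unmoved (no change at the digits printed from compound 2 to compound 4 (within the scatter)). The same fall appears against the 4-fluorophenyl compound (a 2.2-fold lower number from compound 1 to compound 4 (0.34 log units; beyond the scatter)), and in these four compounds the two methoxyphenoxy groups stand together, apart from the phenyl and 4-fluorophenyl groups. No measurement at hand accounts for this shift.

The compounds shown do not separate the ether oxygen from the methoxy group, as plain phenoxy stands in no pair here. From the compounds shown here alone, how an amine or a carboxylic acid on the same ring would read in this assay also remains open.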